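Bromofluorobenzyl Variant After Three Inactive Piperazine Analogues

The source may report more compounds than this note shows. Statements on the series, on what has been measured and on what is new or still open speak of the compounds shown alone.

Compound 1 `CCCn1c(=O)[nH]c2nc(-c3ccc(S(=O)(=O)N4CCN(c5ccccc5C)CC4)cc3)[nH]c2c1=O` reaches only a limit in an assay on CHO cells for displacement of a labelled ligand from adenosine receptor A3 (Homo sapiens), read by scintillation counting, with a stated time of 45 min, in the presence of a further agent that is not named here; a higher number here means a weaker inhibitor, a lower number a stronger inhibitor: > 1000 nM.
Compound 2 `CCCn1c(=O)[nH]c2nc(-c3ccc(S(=O)(=O)N4CCN(Cc5cccc(Br)c5)CC4)cc3)[nH]c2c1=O` reaches only a limit in this assay: > 1000 nM.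
Compound 3 `CCCn1c(=O)[nH]c2nc(-c3ccc(S(=O)(=O)N4CCN(c5cccc(F)c5)CC4)cc3)[nH]c2c1=O` reaches only a limit in this assay: > 1000 nM.

None of these three is a number; each is the point past which the measurement stops reporting, namely (the limit of > 1000 nM in this assay, at which 3 of the 3 values shown sit). Compound 3 therefore does not stand anywhere on a scale; it sits at the same limit as the other two, so no ranking among compounds 1, 2 and 3 can be drawn from these values.

Compound 4 `CCCn1c(=O)[nH]c2nc(-c3ccc(S(=O)(=O)N4CCN(Cc5ccc(Br)c(F)c5)CC4)cc3)[nH]c2c1=O` is the next variation on the shared core, differing from compound 3 by 4-bromo-3-fluorobenzyl in place of 3-fluorophenyl on an amine nitrogen in a ring.

The measured steps that come closest to this change are all blank: a step that the two limits leave unreadable from compound 1 to compound 2, a step that the two limits leave unreadable from compound 1 to compound 3 and a step that the two limits leave unreadable from compound 2 to compound 3. The step from a phenyl to a benzyl group on the ring nitrogen has already been tried between compound 2 and compound 3, and both ends of it lie at the limit, so its size cannot be read. Going by the values given here, there is therefore no measured step from which a direction or a size can be taken, and the expected outcome of a step that the limit leaves unreadable from compound 3 to compound 4 is no readable step at all.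

Compound 4 is thus expected to give 3000 nM in this assay, most likely again only a limit, within 700 nM to 30000 nM.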

Compound 4, inhibition constant: > 1000 nM
Compound 4: no number, only a limit; the forecaster's own chance of this, stated with the estimate: 80%; the middle value does not contradict the limit.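

Compound 4 also ends at a limit and not at a number, so no step linking it to compound 1, compound 2 or compound 3 can be read, and the four compounds share one end point: the limit of > 1000 nM in this assay, at which 4 of the 4 values shown sit.

The compounds shown leave open how strong an inhibitor each one is in this assay, and whether any change on the ring nitrogen alters that strength.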